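Propyl ester on the thiophene analogue: expected receptor inhibition

The source may hold more compounds than are shown below. What is called first, only, known or untested is meant among the compounds shown, and "the series" means these compounds.

Four compounds share a six-membered non-aromatic ring core carrying an ester, and differ in the ester chain and in the aromatic ring attached to the saturated ring carbon. Compound 1 `COC(=O)C1=C(C)N(C)C(=O)NC1c1ccco1` gives 9% in an assay on membranes from HeLa cells for displacement of a labelled ligand from adenosine receptor A3 (Homo sapiens), read by scintillation counting, with a stated time of 180 min, tested at 1 uM; on this read-out higher numbers stand for more inhibition at the one concentration tested (going by the name of the read-out) and lower numbers for less inhibition. Compound 2 `CCCOC(=O)C1=C(C)N(C)C(=O)NC1c1ccco1` gives 8% in this assay; the change ethyl in place of hydrogen on a saturated chain carbon bound to an oxygen next to a carbonyl group made a step of a number 1 percentage points lower from compound 1 to compound 2 (within the scatter). Compound 3 `COC(=O)C1=C(C)N(C)C(=O)NC1c1ccsc1` gives 22% in this assay, the highest of the three measured numbers; its core differs from that of compound 1 by thiophen-3-yl in place of furan-2-yl on a saturated ring carbon, and the step was a number 13 percentage points higher from compound 1 to compound 3 (beyond the scatter).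

Compound 4 `CCCOC(=O)C1=C(C)N(C)C(=O)NC1c1ccsc1` has not yet been measured. It differs from compound 3 by ethyl in place of hydrogen on a saturated chain carbon bound to an oxygen next to a carbonyl group, the same change as from compound 1 to compound 2, occurring twice among these compounds, at the same place each time. Since that change gave a number 1 percentage points lower from compound 1 to compound 2 (within the scatter), the step from compound 3 to compound 4 is expected to be a number 1 percentage points lower from compound 3 to compound 4 (within the scatter), also within the scatter. Compound 4 is therefore estimated at 21%, between 8% and 34%.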

Compound 4, a percentage reported as inhibition, at one concentration (the size of the read-out at that concentration, not a potency): 11%
Beside the measured number, compound 4's estimate is 10 percentage points above it; measured number inside the range.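

In this assay, exchanging methoxycarbonyl for propoxycarbonyl on the thiophen-3-yl compounds gave a number 11 percentage points lower from compound 3 to compound 4 (beyond the scatter), and this step cannot be told apart from the one seen for the same change on the furan-2-yl compounds: the same change on two cores in this assay, a number 1 percentage points lower (within the scatter) from compound 1 to compound 2 and a number 11 percentage points lower (beyond the scatter) from compound 3 to compound 4, 10 percentage points apart, within the scatter of two such steps. The exchange of furan-2-yl for thiophen-3-yl, made here on the propyl esters, gave a number 3 percentage points higher from compound 2 to compound 4 (within the scatter), and it likewise cannot be told apart from its earlier counterpart on the methyl esters: the same change on two cores in this assay, a number 13 percentage points higher (beyond the scatter) from compound 1 to compound 3 and a number 3 percentage points higher (within the scatter) from compound 2 to compound 4, 10 percentage points apart, within the scatter of two such steps. Each change therefore carried over within the scatter between these two settings, but each comparison rests on a single pair of steps, which does not show that either change would carry over the same way to other compounds in the series.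

On these data alone, it remains open how a longer chain such as butyl, or a carboxylic acid in place of the ester, would read out. The same holds for other rings on the saturated ring carbon, such as phenyl or thiophen-2-yl.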